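A few compounds are considered here, and "the series" means these few. Any claim that something is new, unique, unknown or untested is made for them only; others in the source may bear on it.

Measured compounds:
compound 1 `O=[N+]([O-])c1ccc(COC2=NS(=O)(=O)N(Cc3ccc([N+](=O)[O-])cc3)c3ccccc32)cc1`: 53000 nM
compound 2 `Cc1ccc(CN2c3ccccc3C(=O)N(Cc3ccccc3)S2(=O)=O)cc1`: 63000 nM

In a functional assay on MRC5 cells (Homo sapiens) (a higher number here means that more compound is tolerated, a lower number that less compound is tolerated), compound 2 gives 63000 nM, and compound 1 gives 53000 nM; the two numbers lie within the usual scatter of each other, so neither stands apart from the other. Compound 3 `O=C1c2ccccc2N(CCCc2ccccc2)S(=O)(=O)N1Cc1ccccc1` is not yet measured. It differs from compound 2 in one place: phenethyl in place of 4-methylphenyl on a saturated chain carbon bound to a sulfonamide nitrogen in a ring. Within the data shown here, no step between measured compounds is available, and both measured values sit in the same region, so no change beyond the scatter is expected in this assay in either direction. Compound 3 is expected to give 55000 nM, within 25000 nM to 110000 nM, which means an expected step of a 1.1-fold lower number from compound 2 to compound 3 (0.06 log units; within the scatter).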

Compound 3, half-maximal cytotoxic concentration: > 57000 nM
Compound 3 was reported as a limit; the forecaster's own chance of this, stated with the estimate: 20%; middle value at least 1.0-fold (0.01 log units) from the limit.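

In this assay compound 3 gives > 57000 nM, which is a limit; no step can be read between compound 2 and compound 3. Still open, from the compounds shown here alone, is whether phenethyl in place of 4-methylphenyl changes the read-out in this assay at all.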